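Adding a Methoxy Group: What Cell Tolerance Might Show

The compounds below may be only part of what the source reports. "The series", "measured", "known", "first", "only" and "open" are said of these compounds alone.

Of the compounds shown here, two that share a core have so far been tested in an ADME assay on HPC cells (Homo sapiens) for cytotoxicity, with a stated time of 48 h; a higher number here means that more compound is tolerated, a lower number that less compound is tolerated. Compound 1 `Cc1c(C(=O)/C=C/c2cccc([N+](=O)[O-])c2)[n+]([O-])c2ccccc2[n+]1[O-]` gives 46000 nM in this assay. Compound 2 `COc1ccc(/C=C/C(=O)c2c(C)[n+]([O-])c3ccccc3[n+]2[O-])cc1` carries a different group at the far end of the chain; in this assay compound 2 gives 92000 nM. Among the measured compounds shown here, compound 2 holds the higher of the two numbers, yet the gap to compound 1 lies within the usual scatter of repeated measurements, so the two values cannot be told apart, and no step between measured compounds that differ in only one place is available.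

Compound 3 `COc1ccc(/C=C/C(=O)c2c(C)[n+]([O-])c3ccccc3[n+]2[O-])cc1OC` has not yet been measured. It differs from compound 2 by methoxy in place of hydrogen on an aromatic carbon. For the measured compounds named here, nothing among the measured compounds shows how such a change moves the numbers in this assay, so the starting point is the value of compound 2 alone. The step of a 1.2-fold lower number from compound 2 to compound 3 (0.06 log units; within the scatter) is expected to stay within the scatter, with no clear direction. Compound 3 is therefore estimated at 80000 nM, with a likely range from 30000 nM to 200000 nM.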

Compound 3, half-maximal cytotoxic concentration: 142000 nM
Compound 3: middle estimate off by 1.8-fold (0.25 log units), on the low side; measured number inside the range.
By their numbers in this assay, from the lowest: compounds 1, 2 and 3 (each within the scatter of the next, the first and the last beyond it).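

In this assay, putting a methoxy group in place of hydrogen on an aromatic carbon, ortho to a methoxy group and meta to a large group, gives a 1.5-fold higher number from compound 2 to compound 3 (0.19 log units; within the scatter). Among the compounds shown here, this is the first direct comparison of two compounds that differ in only one place, and it shows that compound 2 and compound 3 cannot be told apart here, since repeated measurements of the same compound could differ just as much. Nothing else in hand bears on what lies behind this result, so the pair can only be described and not explained.

From the compounds shown here alone, what remains open is whether this position on the six-membered aromatic ring responds to other groups in the same way: an amine, a carboxylic acid or a longer chain such as ethoxy could give a step that rises clearly above the scatter, or could stay within it as methoxy does. Going by these compounds, it also remains open whether a methoxy group at this position would give a similar step on a compound that carries a nitro group, as compound 1 does.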